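The compounds below may be only part of what the source reports. "The series", "measured", "known", "first", "only" and "open" are said of these compounds alone.

In a physicochemical assay for pharmacokinetics (on this read-out higher numbers stand for a longer-lived compound and lower numbers for a shorter-lived compound), compound 1 `CCOc1oc(=O)c2cc([N+](=O)[O-])ccc2c1Cl` gives < 0.334 h, which is a limit and not a number. Compound 2 `CCCCOc1oc(=O)c2cc([N+](=O)[O-])ccc2c1Cl` gives < 0.334 h, which is also a limit, so compound 2 has no exact position on the scale. The two results sit together: the limit of < 0.334 h in this assay, at which 2 of the 2 values shown sit.

The next compound is compound 3 `CCC(C)Oc1oc(=O)c2cc([N+](=O)[O-])ccc2c1Cl`. The structural change is sec-butyl in place of butyl on an oxygen on an aromatic ring. The two compounds have the same atoms, joined differently.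

Among the measured compounds shown here, only one measured step bears on this change, a step that the two limits leave unreadable from compound 1 to compound 2. It gives no size to carry forward, and it is a different kind of change. The data therefore support no direction, and no step beyond the usual scatter is expected. The expected move is small, with an estimated step that the limit leaves unreadable from compound 2 to compound 3. A further limit in this assay would be no surprise. For compound 3 the estimated half-life is 0.3 h, with an expected range from 0.15 h to 0.8 h.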

Compound 3, half-life: < 0.334 h
Compound 3: only a limit was reported (the forecaster's own chance of this, stated with the estimate: 60%); the middle value does not contradict the limit.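

Compound 3 returns only a limit in this assay, so no step can be read among compound 1, compound 2 and compound 3, whose results all rest at the same limit: the limit of < 0.334 h in this assay, at which 3 of the 3 values shown sit. The compounds shown leave open what the actual half-life of each one is, and whether changing the chain on the oxygen alters it at all.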